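Chain-length variants of a bis-aryl ether leukotriene antagonist series

A few compounds are considered here, and "the series" means these few. Any claim that something is new, unique, unknown or untested is made for them only; others in the source may bear on it.

Measured so far:
compound 1 `CCCc1c(OCCOCCOc2c(C(C)=O)ccc(OCCCC(=O)O)c2CCC)ccc(C(C)=O)c1O`: in a functional assay on ileum (Cavia porcellus) for inhibition of cysteinyl leukotriene receptor (Homo sapiens) (on this read-out lower numbers stand for stronger inhibition and higher numbers for weaker inhibition), compound 1 gives 100 nM
compound 2 `CCCc1c(OCCOCCOc2c(C(C)=O)ccc(OCCCCCC(=O)O)c2CCC)ccc(C(C)=O)c1O`: in this assay compound 2 gives 200 nM
compound 3 `CCCc1c(OCCCOCCCOc2c(C(C)=O)ccc(OCC(=O)O)c2CCC)ccc(C(C)=O)c1O`: in this assay compound 3 gives 400 nM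

Compound 2 differs from compound 1 by 2-carboxyethyl in place of carboxy on a saturated chain carbon, three bonds along the chain from an oxygen on an aromatic ring, a step of a 2.0-fold higher number from compound 1 to compound 2 (0.30 log units; within the scatter). Compound 3 has the same atoms as compound 1 joined differently; the difference between the two cores is not broken down here. Compound 4 `CCCc1c(OCCCOCCCOc2c(C(C)=O)ccc(OCCCC(=O)O)c2CCC)ccc(C(C)=O)c1O` differs from compound 3 by 2-carboxyethyl in place of carboxy on a saturated chain carbon bound to an oxygen on an aromatic ring, the same kind of change as before but at a place bound to an oxygen on an aromatic ring rather than three bonds along the chain from it. Because the earlier step was a 2.0-fold higher number from compound 1 to compound 2 (0.30 log units; within the scatter), and because compound 3 gives 400 nM, the step for compound 4 is expected at a 1.6-fold lower number from compound 3 to compound 4 (0.20 log units; within the scatter). Compound 4 is estimated at 250 nM, within 100 nM to 600 nM.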

Compound 4, half-maximal inhibitory concentration: 200 nM
Compound 4: middle estimate off by 1.3-fold (0.10 log units), on the high side; the measured number falls inside the stated range.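

In this assay the change from carboxy to 2-carboxyethyl gives a 2.0-fold lower number from compound 3 to compound 4 (0.30 log units; within the scatter), and set beside the earlier step it does not carry over unchanged from one core to the other: the same change on two cores in this assay, a 2.0-fold higher number (0.30 log units; within the scatter) from compound 1 to compound 2 and a 2.0-fold lower number (0.30 log units; within the scatter) from compound 3 to compound 4, 4.0-fold (0.60 log units) apart, beyond the scatter of two such steps. Each step alone lies within the scatter, so neither core on its own shows a clear effect of the change; only the gap between the two steps lies beyond it. A single pair on each core does not show what in the cores sets the steps apart, nor how the change would read on a further core.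

Still open, on these data alone, is how a tetrazole or an amide in place of the carboxylic acid would read on either core.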